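From Compound 3 to Compound 4 in the Cytotoxicity Assay

The source may report more compounds than this note shows. Statements on the series, on what has been measured and on what is new or still open speak of the compounds shown alone.

Compound 3 `COC(=O)c1ccc(NCc2cncn2Cc2ccc([N+](=O)[O-])cc2)cc1-c1ccccc1` carries a 4-nitrophenyl group on a saturated chain carbon bound to an aromatic nitrogen. In a toxicity assay on NIH3T3 cells (Mus musculus) for cytotoxicity, read by resazurin assay (on this read-out lower numbers stand for an effect already at smaller amounts and higher numbers for an effect only at larger amounts of compound), compound 3 reaches only a limit, > 10000 nM, and not a number. Compound 1 `COC(=O)c1ccc(NCc2cncn2Cc2cccc(C)c2)cc1-c1ccccc1` shares the core, and in this assay compound 1 likewise gives only a limit, > 10000 nM. Compound 2 `COC(=O)c1ccc(NCc2cncn2Cc2ccccc2OC)cc1-c1ccccc1` has no result in this assay: "not determined" (no result reported). Within the data shown here, the only step among the measured compounds, a step that the two limits leave unreadable from compound 1 to compound 3, cannot be read, as the limit of > 10000 nM in this assay, at which 2 of the 3 values shown sit, holds both of its ends.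

Compound 4 `COC(=O)c1ccc(NCc2cncn2Cc2ccccc2Br)cc1-c1ccccc1` differs from compound 3 by 2-bromophenyl in place of 4-nitrophenyl on a saturated chain carbon bound to an aromatic nitrogen. Among the measured compounds shown here, no measured step bears on this change with a readable size, and the two compounds with results both sit at the limit, so there is no indication of a direction. The expected outcome is a step that the limit leaves unreadable from compound 3 to compound 4, a step no larger than the scatter. Compound 4 is estimated at 15000 nM, with a range from 5000 nM to 50000 nM, and most likely again only a limit.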

Compound 4, half-maximal effective concentration: 10000 nM
The estimate for compound 4 lay 1.5-fold (0.18 log units) above the measured number, within the range that was stated.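

In this assay, among these compounds, compound 4 gives 10000 nM, the first actual number for a group on a saturated chain carbon bound to an aromatic nitrogen. With 2-bromophenyl at this place, the result gives a number no higher from compound 3 to compound 4 (the limit leaves the size open) and a number no higher from compound 1 to compound 4 (the limit leaves the size open), so the change has a direction that can be no more than flat or downward. Neither step can be read for size, because the other two results are limits and not numbers: the limit of > 10000 nM in this assay, at which 2 of the 4 values shown sit.

As far as these compounds go, whether 2-bromophenyl lowers the number at all, or only lands at the edge of what this assay can report, therefore stays open. Equally open, from the compounds shown here alone, is how an amine, a carboxylic acid or a longer chain at this place would read in this assay.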